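This account rests on a few compounds, and the source may have more. Where it says the series, first, only, none or still open, it means among the compounds named here.

Working notes on the series. For the measured compounds named here, only one number exists so far: in a functional assay on HCT-116 cells (Homo sapiens) for antiproliferative activity, read by MTT assay, with a stated time of 72 h (on this read-out higher numbers stand for weaker inhibition and lower numbers for stronger inhibition), compound 1 (`Cc1ccc(N2CCN(C(=S)SCc3ccc4nc(N)nc(N)c4c3)CC2)c(C)c1`) gives 4070 nM as the sole measured result. Going by the values given here, compound 2 (`Nc1nc(N)c2cc(CSC(=S)N3CCN(c4ccccc4F)CC3)ccc2n1`) has no number in this assay, its entry reads "not determined" (no result reported) and so it has no standing on the scale, and no step can start from it. The next member is compound 3 (`Nc1nc(N)c2cc(CSC(=S)N3CCN(c4ncccn4)CC3)ccc2n1`), not yet measured. Among the compounds with values here, its single change is pyrimidin-2-yl in place of 2-fluorophenyl on an amine nitrogen in a ring and in words this is pyrimidin-2-yl in place of 2-fluorophenyl on an amine nitrogen in a ring. Within the data shown here, no pair has been measured across one change, so the data give no guide to the effect of this swap. In this assay, among the measured compounds shown here, no step beyond the scatter is expected in either direction, and the only reference point is compound 1 at 4070 nM for this expectation. With a single measured neighbour the range is kept wide. Compound 3 is estimated at 5000 nM with an expected range from 1500 nM to 17000 nM in this read-out.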

Compound 3, half-maximal inhibitory concentration: 5840 nM
Estimate against measurement, compound 3: 1.2-fold (0.07 log units) below; the measured number falls inside the stated range.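

For the compounds shown here, this gives the first measured step at this position: in this assay the step is a 1.4-fold higher number from compound 1 to compound 3 (0.16 log units; within the scatter), with pyrimidin-2-yl in place of 2,4-dimethylphenyl on an amine nitrogen in a ring. Across this one change, an aromatic ring of carbon only gives way to an aromatic ring with 2 hetero atoms and 2 hydrogen-bond acceptors, and the two compounds stay within the usual scatter of each other, so this read-out does not separate these two groups. The step between compound 2 and compound 3 cannot be read, as compound 2 has no number, and no measured property bears on the result.

Still open, on these data alone, is whether a group of another kind on the same ring nitrogen, such as a benzyl, an acetyl or a plain methyl group, would give a step beyond the scatter. The compounds shown also leave open what a basic amine or a carboxylic acid carried on the aromatic ring at this position would do, since every group measured here is a bare six-membered aromatic ring.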